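Fluoro to Chloro: Expected Effect on Metabolic Stability

This account rests on a few compounds, and the source may have more. Where it says the series, first, only, none or still open, it means among the compounds named here.

Measured so far in an ADME assay on microsomes from liver (Mus musculus) for metabolic stability, read by LC-MS, using NADPH, with a stated time of 45 min, tested at 0.5 uM; on this read-out lower numbers stand for slow clearance and higher numbers for fast clearance:
compound 1 `O=C(CCSc1nc2cc(F)ccc2o1)N1CCS(=O)(=O)CC1` gives 1.5 mL/min/g
compound 2 `O=C(CCSc1nc2cnccc2o1)N1CCCC1` gives 3.1 mL/min/g

Compound 1 stands at the lowest of the two numbers, and compound 2 lies beyond the usual scatter above it. Compound 3 `O=C(CCSc1nc2cc(Cl)ccc2o1)N1CCS(=O)(=O)CC1` is compound 1 with chloro in place of fluoro on an aromatic carbon. Within the data shown here, no measured pair shows this change, so its size cannot be read from the data. The step of a 1.5-fold higher number from compound 1 to compound 3 (0.17 log units; within the scatter) is expected to be small, upward, and close to the edge of the scatter. For compound 3 the expected value is 2.2 mL/min/g, with a range from 1.1 mL/min/g to 4.4 mL/min/g.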

Compound 3, intrinsic clearance in a liver preparation (reported as CLH), per the amount of preparation that the assay uses: 2.3 mL/min/g
Beside the measured number, compound 3's estimate is 1.0-fold (0.02 log units) below it; low and high end bracket the measured number.
By their numbers in this assay, from the lowest: compounds 1, 3 and 2 (each within the scatter of the next, the first and the last beyond it).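

In this assay, among these compounds, the first single-place change on the core of compound 1 gives a step of a 1.5-fold higher number from compound 1 to compound 3 (0.19 log units; within the scatter) that stays within the usual scatter, so at this aromatic carbon, fluoro and chloro cannot be told apart on this read-out. Nothing measured here points to a cause for this step. Going by these compounds, whether an amine, a methoxy group or a nitrile at this place would move the number beyond the scatter remains open. So does whether the same change gives a similar step with a different amide.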